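Amide substituent changes on a diaryl urea series

The compounds below may be only part of what the source reports. "The series", "measured", "known", "first", "only" and "open" are said of these compounds alone.

Measured in a functional assay on HT-29 cells (Homo sapiens) for inhibition, read by MTT assay, with a stated time of 120 h; a lower number here means a stronger inhibitor, a higher number a weaker inhibitor:
Compound 1, `C/C(=C\C(=O)N1CC(C)OC(C)C1)c1ccc(NC(=O)Nc2ccc(Cl)c(C(F)(F)F)c2)cc1` — 26200 nM
Compound 2, `CNC(=O)/C=C(\C)c1ccc(NC(=O)Nc2ccc(Cl)c(C(F)(F)F)c2)cc1` — > 50000 nM

Compound 2 stands at the edge of what this assay can report: for compound 2 the value is a limit, > 50000 nM, not a number, as the limit of > 50000 nM in this assay, at which 1 of the 2 values shown sits, records. For the measured compounds named here, the one measured step, an at least 1.9-fold higher number from compound 1 to compound 2 (0.28 log units; that floor lies within the scatter), is for that reason itself only a floor. Compound 3, `C/C(=C\C(=O)NC(C)c1ccccc1)c1ccc(NC(=O)Nc2ccc(Cl)c(C(F)(F)F)c2)cc1`, carries 1-phenylethyl in place of methyl on an amide-type nitrogen. Going by the values given here, no measured step touches a change of this kind; the only comparison concerns the exchange of the dimethylmorpholinyl amide for the methylamide, and it ends at the limit. The expected step, an at least 1.6-fold lower number from compound 2 to compound 3 (0.22 log units; that floor lies within the scatter), is a modest move back toward a measurable number, though a limit remains nearly as likely as a value. The estimate for compound 3 is 30000 nM, within 8000 nM to 100000 nM.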

Compound 3, half-maximal inhibitory concentration: > 50000 nM
Compound 3 ended at the assay's limit; the forecaster's own chance of this, stated with the estimate: 45%; middle value at least 1.6-fold (0.22 log units) away from the limit.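

In this assay compound 3 also returns no number, only a limit, so a second amide joins compound 2 at the same ceiling: the limit of > 50000 nM in this assay, at which 2 of the 3 values shown sit. Putting 1-phenylethyl in place of methyl on the amide-type nitrogen, which adds a six-membered aromatic ring, did not bring the series back to a measurable value, and the step between compound 2 and compound 3 cannot be read, as both ends are limits. Measured from the 2,6-dimethylmorpholin-4-yl amide, the exchange gives an at least 1.9-fold higher number from compound 1 to compound 3 (0.28 log units; that floor lies within the scatter), so compound 1 remains the only one of the three with a number.

From the compounds shown here alone, how far compound 2 and compound 3 actually lie from compound 1 stays open. Also open, going by these compounds, is what a piperazine or an unsubstituted morpholine would give on the same carbonyl carbon.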